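The source may report more compounds than this note shows. Statements on the series, on what has been measured and on what is new or still open speak of the compounds shown alone.

Measured so far in an ADME assay on isolated protein for inhibition of Amine oxidase [flavin-containing] A (Homo sapiens), read by fluorescence and Amplex Red, with stated times of 15 min and 20 min; on this read-out lower numbers stand for stronger inhibition and higher numbers for weaker inhibition:
compound 1 `C#CCN(CCCCOc1ccc2ccc(=O)oc2c1)Cc1ccccc1`, giving 89400 nM
compound 2 `C#CCN(CCCOc1ccc2ccc(=O)oc2c1)Cc1ccc(F)c(F)c1`, giving 49200 nM
compound 3 `C#CCN(C)CCCCOc1ccc2ccc(=O)oc2c1`, giving 3280 nM

Compound 2 stands second of the three numbers. Its value and that of compound 1 lie within the usual scatter of each other, so no order can be read between them; its value and that of compound 3, a methyl-bearing amine, are well apart, beyond the scatter. Among the compounds with values here, the only measured step with one change, a 27-fold lower number from compound 1 to compound 3 (1.44 log units; beyond the scatter), concerns the group on the saturated chain carbon bound to the amine nitrogen and does not touch the aromatic ring.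

Compound 4 `C#CCN(CCCOc1ccc2ccc(=O)oc2c1)Cc1cccc(F)c1` differs from compound 2 by hydrogen in place of fluoro on an aromatic carbon. Within the data shown here, no measured step bears on this change: no pair differs only by a fluoro on that ring. The closest comparison, compound 1 against compound 2, also differs in chain length and is within the scatter, so it gives no direction.

The estimated step of a 1.2-fold higher number from compound 2 to compound 4 (0.09 log units; within the scatter) is therefore expected to lie within the scatter. Compound 4 is expected to give about 60000 nM, with a range from 25000 nM to 150000 nM.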

Compound 4, half-maximal inhibitory concentration: 29300 nM
The estimate for compound 4 lay 2.0-fold (0.31 log units) above the measured number, and the stated range covers the measured number.
By their numbers in this assay, from the lowest: compound 3; then compounds 4, 2 and 1 (each within the scatter of the next, the first and the last beyond it).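

In this assay, within the data shown here, the change from 3,4-difluorobenzyl to 3-fluorobenzyl, a 1.7-fold lower number from compound 2 to compound 4 (0.23 log units; within the scatter), gives the first direct reading of a change on this aromatic ring, and it lies within the scatter. At this carbon, ortho to a fluoro group and para to a large group, hydrogen in place of fluoro therefore leaves no readable difference, whereas the earlier step concerned only the group on the chain carbon bound to the amine nitrogen. The data at hand offer no explanation for this result.

The compounds shown leave open whether the fluoro that remains in compound 4 affects the number. They also leave open whether a chloro, methoxy or nitrile group at the same carbon would give a step beyond the scatter.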